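From an alkyl ether to an aminoalkyl ether

The source may hold more compounds than are shown below. What is called first, only, known or untested is meant among the compounds shown, and "the series" means these compounds.

Measured in a functional assay on DU-145 cells (Homo sapiens) for antiproliferative activity, read by WST assay, with a stated time of 3 days; a lower number here means a stronger inhibitor, a higher number a weaker inhibitor:
- Compound 1 `CCCCCOc1c(-c2cc(OC)c(OC)c(OC)c2)oc2ccccc2c1=O`: > 50000 nM (a limit)
- Compound 2 `CCCCCCOc1c(-c2cc(OC)c(OC)c(OC)c2)oc2ccccc2c1=O`: > 50000 nM (a limit)
- Compound 3 `CCCC(C)Oc1c(-c2cc(OC)c(OC)c(OC)c2)oc2ccccc2c1=O`: > 50000 nM (a limit)

No number is yet available in this series, and the record holds only (the limit of > 50000 nM in this assay, at which 3 of the 3 values shown sit). Compound 3 gives > 50000 nM, which is a limit and not a number.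

The next change leads to compound 4 `CCCN(CCC)CCCOc1c(-c2cc(OC)c(OC)c(OC)c2)oc2ccccc2c1=O`, with 3-(dipropylamino)propyl in place of 1-methylbutyl on an oxygen on an aromatic ring.

Within the data shown here, three measured steps bear on this only loosely: a step that the two limits leave unreadable from compound 1 to compound 2, a step that the two limits leave unreadable from compound 1 to compound 3 and a step that the two limits leave unreadable from compound 2 to compound 3. Each swaps one chain without nitrogen for another, and none has a readable size to carry over. The estimate therefore rests on the structural change alone, and it is uncertain. A moderate move towards stronger inhibition is expected, though compound 4 may yet stay at the limit. The expected change is an at least 5.0-fold lower number from compound 3 to compound 4 (0.69 log units; beyond the scatter). Compound 4 is estimated at 10000 nM, within an expected range of 2500 nM to 40000 nM.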

Compound 4, half-maximal inhibitory concentration: > 50000 nM
Compound 4 ended at the assay's limit; the forecaster's own chance of this, stated with the estimate: 20%; middle value at least 5.0-fold (0.69 log units) away from the limit.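

In this assay, among these compounds, compound 4 gives > 50000 nM as a limit and not a number, so no step from compound 1, compound 2 or compound 3 to compound 4 can be read. The compounds shown leave open what size any of these chain changes has.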